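A Cyano for a Methoxy on a Shared Core

This account rests on a few compounds, and the source may have more. Where it says the series, first, only, none or still open, it means among the compounds named here.

Among the compounds with values here, compound 1 `C/C=C/C(=O)Nc1cccc(Oc2nc(Nc3cccc(OC)c3)nc3ccsc23)c1` is the only member of this small set with a number: in an ADME assay on L02 cells (Homo sapiens) for inhibition, read by MTT assay, with a stated time of 72 h (on this read-out lower numbers stand for stronger inhibition and higher numbers for weaker inhibition), compound 1 gives 46000 nM. Compound 2 `COc1cccc(Nc2nc(Oc3cccc(NC(=O)/C=C/C(C)C)c3)c3sccc3n2)c1` shares the core, but in this assay compound 2 gives "not determined" (no result reported), so compound 1 stands alone on the numbers shown, with nothing to rank it against. Compound 3 `C/C=C/C(=O)Nc1cccc(Oc2nc(Nc3cccc(C#N)c3)nc3ccsc23)c1` is not yet measured. It differs from compound 1 in one place, (cyano in place of methoxy on an aromatic carbon), that is, cyano in place of methoxy on an aromatic carbon. Within the data shown here, no pair of measured compounds shows what such a swap does here, so the size of the step can only be guessed; with nothing in the data pointing either way, a step within the usual scatter of this assay, or a small one in either direction, is expected. Compound 3 is therefore estimated at 40000 nM, with a range from 13000 nM to 120000 nM. The step that this estimate means is expected to be a 1.2-fold lower number from compound 1 to compound 3 (0.06 log units; within the scatter).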

Compound 3, half-maximal inhibitory concentration: 47900 nM
Estimate against measurement, compound 3: 1.2-fold (0.08 log units) below; the range from low to high includes it.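

In this assay, cyano in place of methoxy on an aromatic carbon, meta to a large group, gives a 1.0-fold higher number from compound 1 to compound 3 (0.02 log units; within the scatter). Within the data shown here, this is the first readable step at this position, and it shows that on the shared core the two groups cannot be told apart in this read-out. The result holds for this single pair only, and nothing presented here bears on the reason for it.

The compounds shown leave open what an amine or a carboxylic acid on that aromatic carbon would give in this assay, and whether a longer chain there would stay as close to compound 1 as cyano does. Among these compounds, whether the swap would read the same with a different amide chain also stays open, and no step involving compound 2 can be read.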